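This account rests on a few compounds, and the source may have more. Where it says the series, first, only, none or still open, it means among the compounds named here.

In a functional assay on HCT-15 cells (Homo sapiens) for inhibition, read by sulforhodamine B assay, with a stated time of 48 h, tested at 10 uM (on this read-out lower numbers stand for less inhibition and higher numbers for more inhibition at the one concentration tested (going by the name of the read-out)), the measured compounds stand as follows:

- compound 1, `COc1ccc(-c2cn3ccnc3c(-c3ccc4ncn(C5CCCCC5)c4c3)n2)cc1`, gives 78.8%
- compound 2, `Clc1ccc(-c2cn3ccnc3c(-c3ccc4ncn(C5CCCCC5)c4c3)n2)cc1`, gives 15.5%
- compound 3, `COc1ccccc1-c1cn2ccnc2c(-c2ccc3ncn(C4CCCCC4)c3c2)n1`, gives 33.6%

Compound 3 stands second highest of the three numbers: below compound 1 by a number 45.2 percentage points lower from compound 1 to compound 3 (beyond the scatter) and above compound 2 by a number 18.1 percentage points higher from compound 2 to compound 3 (beyond the scatter). Compound 4, `Fc1ccccc1-c1cn2ccnc2c(-c2ccc3ncn(C4CCCCC4)c3c2)n1`, differs from compound 3 in one place: fluoro in place of methoxy on an aromatic carbon. Among the compounds with values here, two measured steps bear on this change. Swapping methoxy for a halogen, as in the step of a number 63.3 percentage points lower from compound 1 to compound 2 (beyond the scatter), lowered the number sharply, though there the group sat as 4-methoxyphenyl rather than 2-methoxyphenyl. The step of a number 45.2 percentage points lower from compound 1 to compound 3 (beyond the scatter) shows how much lower the 2-methoxyphenyl compound already stands, so the room for a further drop is smaller. Within the data shown here, on balance a drop beyond the scatter in this assay is expected for compound 4, smaller than the one from compound 1 to compound 2, because of a number 63.3 percentage points lower from compound 1 to compound 2 (beyond the scatter) set against the lower starting point of compound 3 at 33.6%. The expected step is a number 13.6 percentage points lower from compound 3 to compound 4 (beyond the scatter). Compound 4 is therefore estimated at 20%, in a range from 5% to 42%.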

Compound 4, a percentage reported as inhibition, at one concentration (the size of the read-out at that concentration, not a potency): 6.18%
Compound 4: the middle estimate sits 13.8 percentage points above what was measured; the range from low to high includes it.
By their numbers in this assay, from the lowest: compounds 4 and 2 (each within the scatter of the next); then compound 3; then compound 1.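

In this assay, the 2-methoxyphenyl compound did not mark the low end for this position: with fluoro in place of methoxy, ortho to a large group, the result is a number 27.4 percentage points lower from compound 3 to compound 4 (beyond the scatter) and the drop is beyond the scatter. Replacing methoxy with a halogen has now lowered the number in both the 4-methoxyphenyl and the 2-methoxyphenyl compounds, although the halogens differ, chloro in one and fluoro in the other. The halogen-bearing compounds cannot be told apart, with a number 9.3 percentage points lower from compound 2 to compound 4 (within the scatter) as their step, whereas the 4-methoxyphenyl compound stands well clear, with a number 72.6 percentage points lower from compound 1 to compound 4 (beyond the scatter) as its step.

On these data alone, whether an amino or hydroxyl group in place of the methoxy would hold the number up remains open, as does the effect of fluoro in the 4-substituted phenyl. Nothing shown gives a reason for these steps.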